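Shortening the tert-Butyl of Compound 2 to Isopropyl

The compounds below may be only part of what the source reports. "The series", "measured", "known", "first", "only" and "open" are said of these compounds alone.

Compound 1, `Cc1ncn2c(O)nncc12`, gives > 48000 nM in a functional assay for inhibition, with Homo sapiens as the target; a lower number here means a stronger inhibitor, a higher number a weaker inhibitor.
Compound 2, `Cc1nc(C(C)(C)C)n2c(O)nncc12`, gives 31000 nM in this assay.

The result for compound 1 in this assay is a limit of the assay, not a number. For the measured compounds named here, compound 2 thus holds the only number among the two results, the other being a limit. Compound 3, `Cc1nc(C(C)C)n2c(O)nncc12`, remains to be measured; it differs from compound 2 by hydrogen in place of methyl on a saturated chain carbon bound to an aromatic carbon and two saturated chain carbons. Going by the values given here, the one measured step that bears on this change is the one in which tert-butyl replaced hydrogen, an at least 1.5-fold lower number from compound 1 to compound 2 (0.18 log units; that floor lies within the scatter), a step whose floor lies within the scatter and which rests on a limit (the limit of > 48000 nM in this assay, at which 1 of the 2 values shown sits). Removing a single methyl from that tert-butyl undoes only part of that change, so no step beyond the scatter is expected in this assay. The step expected here is a 1.3-fold higher number from compound 2 to compound 3 (0.11 log units; within the scatter). Compound 3 is therefore estimated at 40000 nM, within 15000 nM to 100000 nM, with a fair chance that only a limit is reported.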

Compound 3, half-maximal inhibitory concentration: > 48000 nM
Compound 3 ended at the assay's limit (the forecaster's own chance of this, stated with the estimate: 35%); middle value at least 1.2-fold (0.07 log units) from the limit.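

Removing one methyl from the tert-butyl of compound 2 gives, in this assay, an at least 1.5-fold higher number from compound 2 to compound 3 (0.18 log units; that floor lies within the scatter), so this change can be read only as a floor, and that floor does not separate the two compounds. The step between compound 1 and compound 3 cannot be read, as both results are limits of the assay and not numbers. On this aromatic carbon, isopropyl now stands with hydrogen at the limit, and tert-butyl is the only group shown that gives a number, a picture that rests on a single value and otherwise on limits: the limit of > 48000 nM in this assay, at which 2 of the 3 values shown sit.

On these data alone, how far compound 3 actually lies from compound 2 stays open, and so does whether any group here gives a step beyond the scatter. The compounds shown do not tell how a longer chain, a cyclopropyl ring or an amine on this carbon would read.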